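Swapping 3-iodophenyl for 4-carboxycyclohexyl in compound 2

A few compounds are considered here, and "the series" means these few. Any claim that something is new, unique, unknown or untested is made for them only; others in the source may bear on it.

In a functional assay on BXPC-3 cells (Homo sapiens) for cytotoxicity, read by MTT assay (a lower number here means a stronger inhibitor, a higher number a weaker inhibitor), compound 1 `Oc1ccc(CN(Cc2cccc(C(F)(F)F)c2)Cc2ccc(O)c3ncccc23)c2cccnc12` gives 167 nM and compound 2 `Oc1ccc(CN(Cc2cccc(I)c2)Cc2ccc(O)c3ncccc23)c2cccnc12` gives 2590 nM, so compound 2 holds the higher of the two numbers. For the measured compounds named here, the one measured step is a 16-fold higher number from compound 1 to compound 2 (1.19 log units; beyond the scatter), with iodo in place of trifluoromethyl on an aromatic carbon.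

Compound 3 `O=C(O)C1CCC(CN(Cc2ccc(O)c3ncccc23)Cc2ccc(O)c3ncccc23)CC1` differs from compound 2 by 4-carboxycyclohexyl in place of 3-iodophenyl on a saturated chain carbon bound to an amine nitrogen. The iodo group of the measured step therefore leaves together with its whole ring.

Going by the values given here, no measured step replaces an aromatic ring with a non-aromatic one or brings in a carboxy group, so the available evidence bears only indirectly. The large step of a 16-fold higher number from compound 1 to compound 2 (1.19 log units; beyond the scatter) shows that one substituent change on this group moved the number well beyond the scatter, so a wide range is expected here. A moderate move toward a higher number in this assay is expected, and the estimated step is a 2.3-fold higher number from compound 2 to compound 3 (0.36 log units; beyond the scatter). Compound 3 is expected at 6000 nM, with an estimated range of 1500 nM to 25000 nM.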

Compound 3, half-maximal inhibitory concentration: 4340 nM
For compound 3 the middle estimate is 1.4-fold (0.14 log units) above the measured one, and the stated range covers the measured number.
By their numbers in this assay, from the lowest: compound 1; then compounds 2 and 3 (each within the scatter of the next).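

In this assay, 4-carboxycyclohexyl in place of 3-iodophenyl on a saturated chain carbon bound to an amine nitrogen gives a 1.7-fold higher number from compound 2 to compound 3 (0.22 log units; within the scatter), so at this place a non-aromatic ring bearing a carboxy group and an aromatic iodo-substituted ring cannot be told apart by their numbers. The same group in place of 3-(trifluoromethyl)phenyl gives a 26-fold higher number from compound 1 to compound 3 (1.41 log units; beyond the scatter), which leaves compound 1 apart, and compound 2 shows that an aromatic ring at this place does not by itself go with the low number of compound 1. Nothing available on these compounds accounts for the numbers.

The loss of aromaticity and the arrival of the carboxy group come together in compound 3, so their separate contributions stay unresolved, and a plain cyclohexyl or a 4-carboxyphenyl at this place would be needed to divide them. Also open, on these data alone, is whether any other substituent on the aromatic ring, such as a nitrile or a methoxy group, comes close to the trifluoromethyl of compound 1 or falls with the iodo of compound 2.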